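This account rests on a few compounds, and the source may have more. Where it says the series, first, only, none or still open, it means among the compounds named here.

Measured in a functional assay on the whole organism (integument) for inhibition, with Chilo suppressalis as the target, read by scintillation counting, with a stated time of 72 h; a higher number here means a weaker inhibitor, a lower number a stronger inhibitor:
Compound 1 `COc1cccc(OC)c1C(=O)Nc1nnc(-c2ccc(Cl)cc2)s1` gives 58.9 nM.
Compound 2 `COc1cccc(OC)c1C(=O)Nc1nnc(-c2ccccc2)s1` gives 2950 nM.
Compound 3 `COc1cccc(OC)c1C(=O)Nc1nnc(-c2ccc(Br)cc2)s1` gives 66.1 nM.

Compound 3 stands second highest of the three numbers. Compound 1 is nearest to it, with a 1.1-fold higher number from compound 1 to compound 3 (0.05 log units; within the scatter); compound 2 is furthest, with a 45-fold lower number from compound 2 to compound 3 (1.65 log units; beyond the scatter) between them.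

Compound 4 `COc1cccc(OC)c1C(=O)Nc1nnc(-c2ccc([N+](=O)[O-])cc2)s1` is not yet measured. It differs from compound 3 in one place: nitro in place of bromo on an aromatic carbon.

Going by the values given here, three measured steps touch this position. Taking the halogen away gave a 50-fold higher number from compound 1 to compound 2 (1.70 log units; beyond the scatter), and putting a halogen in gave a 45-fold lower number from compound 2 to compound 3 (1.65 log units; beyond the scatter), so the group at this place carries most of the spread seen in this assay. Exchanging one halogen for another gave a 1.1-fold higher number from compound 1 to compound 3 (0.05 log units; within the scatter). Among the compounds with values here, no measured step shows a non-halogen group at this place, so whether nitro sits with the halogens or with hydrogen is open. Keeping a substituent there, compound 4 is expected to stay nearer compound 3 than compound 2, with a 2.3-fold higher number from compound 3 to compound 4 (0.36 log units; beyond the scatter) expected. The estimate for compound 4 in this assay is 150 nM, with a range from 40 nM to 800 nM.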

Compound 4, half-maximal inhibitory concentration: 355 nM
Estimate against measurement, compound 4: 2.4-fold (0.37 log units) below; the measured number falls inside the stated range.
By their numbers in this assay, from the lowest: compounds 1 and 3 (each within the scatter of the next); then compound 4; then compound 2.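

Nitro is the first non-halogen group seen at this position in this assay, and it separates from both halogens, with a 5.4-fold higher number from compound 3 to compound 4 (0.73 log units; beyond the scatter) and a 6.0-fold higher number from compound 1 to compound 4 (0.78 log units; beyond the scatter) while also standing clear of hydrogen, with an 8.3-fold lower number from compound 2 to compound 4 (0.92 log units; beyond the scatter) on the other side. The position therefore does more than tell a substituent from none: the 4-nitrophenyl compound keeps only part of the gain that chloro and bromo give over the bare phenyl, a gradation the halogen exchange alone could not reveal. Nothing available here accounts for this order.

Where an amine, a methoxy group or a carboxylic acid would fall on this scale remains open, as does whether fluoro or iodo would match chloro and bromo. On these data alone, with the rest of the core of compound 1 held constant throughout, it also remains open whether this order would hold after a change elsewhere in the molecule.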